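A Methyl Group Added to the Amino of Compound 1

A few compounds are considered here, and "the series" means these few. Any claim that something is new, unique, unknown or untested is made for them only; others in the source may bear on it.

Compound 1 `Nc1nc(=O)ccn1[C@@H]1O[C@H](COP(=O)(O)O)[C@@H](O)[C@H]1O` is the reference point of this small set. For the measured compounds named here, in an in vitro functional assay on 1321-N1 cells for agonist activity at P2Y purinoceptor 4 (Homo sapiens), read by scintillation proximity assay and inositol phosphate accumulation (a higher number here means that more compound is needed for the effect, a lower number that less compound is needed), compound 1 gives 4980 nM, and this is the only value in the set that is a number rather than a limit. Compound 2 `O=c1ccn([C@@H]2O[C@H](COP(=O)(O)OP(=O)(O)O)[C@@H](O)[C@H]2O)c(SCCc2ccccc2)n1` returns only a limit in this assay, namely >= 100000 nM. Compound 3 `O=c1[nH]c(=S)ccn1[C@@H]1O[C@H](COP(=O)(O)O)[C@@H](O)[C@H]1O` likewise returns only a limit in this assay, namely > 100000 nM. Two of the three values thus sit at a limit: the limit of > 100000 nM in this assay, at which 1 of the 3 values shown sits, and (the limit of >= 100000 nM in this assay, at which 1 of the 3 values shown sits). Compound 1 therefore stands alone as the single point on which a comparison can rest.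

Compound 4 `CNc1nc(=O)ccn1[C@@H]1O[C@H](COP(=O)(O)O)[C@@H](O)[C@H]1O` is the compound still to be measured. It differs from compound 1 in one place: methyl in place of hydrogen on a nitrogen on an aromatic ring. Cut one bond further out, the same change reads amino to methylamino.

Going by the values given here, no pair of measured compounds that differ in a single place is available, so the size of such a step cannot be read from the data. For compound 4 the expected step is a 1.6-fold higher number from compound 1 to compound 4 (0.21 log units; within the scatter), judged to be small and close to the usual scatter. Compound 4 is accordingly estimated at 8000 nM in this assay, with a range from 2000 nM to 40000 nM.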

Compound 4, half-maximal effective concentration: > 100000 nM
Compound 4 gave a limit, no number; the forecaster's own chance of this, stated with the estimate: 25%; middle value at least 12-fold (1.09 log units) away from the limit.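

Until now no single change could be followed in this set, as every compound differed from the others in more than one place. Compound 4 supplies the first such comparison, and it shows that this position is sensitive to a very small change: replacing one hydrogen with methyl, on a nitrogen on an aromatic ring, gives an at least 20-fold higher number from compound 1 to compound 4 (1.30 log units; beyond the scatter). In this assay compound 4 gives > 100000 nM, which is a limit and not a number, and it joins the other values held at that limit: the limit of > 100000 nM in this assay, at which 2 of the 4 values shown sit.

The compounds shown leave open whether this loss belongs to methyl alone or extends to other groups on the same nitrogen, such as ethyl, hydroxy or acetyl, and a measured number for any of these would help define what the position accepts. They also leave open whether the same change acts in the same way on a core with a diphosphate chain, and the steps involving compound 2 and compound 3 cannot be read.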